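Methyl for Hydrogen in a Series Sitting at the Assay Limit

The source may report more compounds than this note shows. Statements on the series, on what has been measured and on what is new or still open speak of the compounds shown alone.

Of the compounds shown here, three have so far been tested in an assay on isolated protein for inhibition of high affinity 3',5'-cyclic-AMP phosphodiesterase 7A (Homo sapiens), read by cAMP accumulation, with a stated time of 10 min; on this read-out lower numbers stand for stronger inhibition and higher numbers for weaker inhibition. Compound 1 `COc1nc2c(c(=O)n(C)c(=O)n2C)n1CC(=O)Nc1cccc(Cl)c1` gives > 200000 nM, which is a limit of the assay rather than a number. Compound 2 `CCOc1nc2c(c(=O)n(C)c(=O)n2C)n1CC(=O)Nc1cccc(Cl)c1` gives > 200000 nM, again a limit. Compound 3 `CCOc1nc2c(c(=O)n(C)c(=O)n2C)n1CC(=O)Nc1ccc(C(C)C)cc1` gives > 200000 nM, also a limit. Compound 2 differs from compound 1 by methyl in place of hydrogen on a saturated chain carbon bound to an oxygen on an aromatic ring, and the measured result is a step that the two limits leave unreadable from compound 1 to compound 2. Compound 3 carries a different group on the amide nitrogen, and here a step that the two limits leave unreadable from compound 2 to compound 3. The difference between the cores of compound 1 and compound 3 is not broken down here. Among the compounds with values here, all three values rest on (the limit of > 200000 nM in this assay, at which 3 of the 3 values shown sit), so no step among them can be sized.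

Compound 4 `CCOc1nc2c(c(=O)n(C)c(=O)n2C)n1CC(=O)Nc1ccc(C(C)(C)C)cc1` has not yet been measured. It differs from compound 3 by methyl in place of hydrogen on a saturated chain carbon bound to an aromatic carbon and two saturated chain carbons. This is the same kind of change as from compound 1 to compound 2, but not the same: there the carbon was bound to an oxygen on an aromatic ring, whereas here it is bound to an aromatic carbon and two saturated chain carbons. Since every measured compound sits at the limit of > 200000 nM in this assay, at which 3 of the 3 values shown sit, the step from compound 3 to compound 4 is expected to be a step that the limit leaves unreadable from compound 3 to compound 4, meaning no readable change. Compound 4 is accordingly expected to give about 300000 nM in this assay. For compound 4 the expected range runs from 100000 nM to 1000000 nM, with a further limit reading the most likely outcome.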

Compound 4, half-maximal inhibitory concentration: > 200000 nM
Compound 4: no number, only a limit; the forecaster's own chance of this, stated with the estimate: 85%; the middle value lies beyond the limit too.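

In this assay compound 4 gives > 200000 nM, which is a limit and not a number. Its steps from compound 3 and from compound 2 cannot be read, and all four compounds rest on the same limit: the limit of > 200000 nM in this assay, at which 4 of the 4 values shown sit.

The compounds shown leave open how far any of these changes shifts inhibition, and which structure would give a value that can be read as a number.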